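Carboxyazetidine to carboxypiperidine on a stilbene benzylamine

This account rests on a few compounds, and the source may have more. Where it says the series, first, only, none or still open, it means among the compounds named here.

Compound 1 `COc1ccc(/C=C\c2cc(OC)c(OC)c(OC)c2)cc1OCc1ccc(CN2CC(C(=O)O)C2)cc1`: > 10000 nM
Compound 2 `COc1ccc(/C=C\c2cc(OC)c(OC)c(OC)c2)cc1OCc1ccc(CN2CC[C@@H](O)C2)cc1`: 6200 nM
Compound 3 `COc1ccc(/C=C\c2cc(OC)c(OC)c(OC)c2)cc1OCc1ccc(CNCCO)cc1`: 5900 nM

These three compounds share one core and differ only in the amine attached to the saturated chain carbon bound to an aromatic carbon. In a functional assay on HepG2 cells (Homo sapiens) for antiproliferative activity, read by CCK-8 assay, with a stated time of 48 h (on this read-out higher numbers stand for weaker inhibition and lower numbers for stronger inhibition), compound 1 reaches only the limit of the assay, > 10000 nM; this is a limit and not a number (the limit of > 10000 nM in this assay, at which 1 of the 3 values shown sits). Compound 2 gives 6200 nM in this assay, and compound 3 gives 5900 nM. The two measured steps from compound 1 are an at least 1.6-fold lower number from compound 1 to compound 2 (0.20 log units; that floor lies within the scatter) and an at least 1.6-fold lower number from compound 1 to compound 3 (0.22 log units; that floor lies within the scatter); both floors lie within the scatter, so neither shows a clear gain.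

Compound 4 `COc1ccc(/C=C\c2cc(OC)c(OC)c(OC)c2)cc1OCc1ccc(CN2CCCC[C@@H]2C(=O)O)cc1` is not yet measured. Its difference from compound 1 is 2-carboxypiperidin-1-yl in place of 3-carboxyazetidin-1-yl on a saturated chain carbon bound to an aromatic carbon. Unlike compounds 2 and 3, compound 4 keeps a carboxylic acid on the ring, so the measured steps give no reason to expect a drop away from the limit. The step from compound 1 to compound 4 is therefore expected to be a number no higher from compound 1 to compound 4 (the limit leaves the size open), with a real chance that only a limit is reported again. For compound 4 the estimated value in this assay is 10000 nM, between 4000 nM and 25000 nM.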

Compound 4, half-maximal inhibitory concentration: > 10000 nM
Compound 4 ended at the assay's limit (the forecaster's own chance of this, stated with the estimate: 55%); the middle value lies on the limit itself.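

Compound 4 now joins compound 1 at the limit in this assay, so two different carboxylic acid rings, a four-membered and a six-membered one that also carries a defined stereocentre, end in the same place: the limit of > 10000 nM in this assay, at which 2 of the 4 values shown sit. Both values are limits, and the step between compound 1 and compound 4 cannot be read. Against the two amines carrying a hydroxyl group, the result gives an at least 1.6-fold higher number from compound 3 to compound 4 (0.22 log units; that floor lies within the scatter) and an at least 1.6-fold higher number from compound 2 to compound 4 (0.20 log units; that floor lies within the scatter); both floors lie within the scatter, so compound 4 is not shown to be clearly weaker than either, and the split between the two acids at the limit and the two hydroxyl amines with numbers rests on these four compounds alone.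

Going by these compounds, it remains open whether the carboxylic acid itself matters for this read-out, which a plain piperidin-1-yl group or a methyl ester of the same acid would test. Also open, on these data alone, is what a 3-carboxypyrrolidin-1-yl group or the opposite configuration of 2-carboxypiperidin-1-yl would give on the shared core.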